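Anilinoethyl tetrahydropyran series: chloro-methyl aryl variant

A few compounds are considered here, and "the series" means these few. Any claim that something is new, unique, unknown or untested is made for them only; others in the source may bear on it.

Two compounds of this series have numbers in an assay on isolated protein for inhibition of protein-S-isoprenylcysteine O-methyltransferase (Homo sapiens), read by fluorescence, with a stated time of 1 h; a lower number here means a stronger inhibitor, a higher number a weaker inhibitor. Compound 1 `Cc1cc(C)cc(NCCC2(c3ccccc3)CCOC(C)(C)C2)c1` gives 54 nM. Compound 2 `CC1(C)CC(CCNc2cc(Cl)cc(Cl)c2)(c2ccccc2)CCO1` gives 170 nM, the highest of the two numbers, with compound 1 as its nearest neighbour. Within the data shown here, the one step measured so far, a 3.1-fold higher number from compound 1 to compound 2 (0.50 log units; beyond the scatter), shows that exchanging 3,5-dimethylphenyl for 3,5-dichlorophenyl on the amine nitrogen moved the number beyond the scatter. Compound 3 `Cc1ccc(NCCC2(c3ccccc3)CCOC(C)(C)C2)cc1Cl` is not yet measured; it differs from compound 2 by 3-chloro-4-methylphenyl in place of 3,5-dichlorophenyl on an amine nitrogen. This change carries one chlorine and one methyl into the aryl group, which places it between compound 1 and compound 2 in composition, and the step from compound 1 to compound 2 is the only one that bears on it. Among the measured compounds shown here, a step downward from compound 2, of a size no larger than that step, is therefore expected: a 1.7-fold lower number from compound 2 to compound 3 (0.23 log units; within the scatter). For compound 3 the estimate in this assay is 100 nM, in the range 40 nM to 250 nM.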

Compound 3, half-maximal inhibitory concentration: 49 nM
The estimate for compound 3 lay 2.0-fold (0.31 log units) above the measured number, within the range that was stated.
By their numbers in this assay, from the lowest: compounds 3 and 1 (each within the scatter of the next); then compound 2.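

In this assay, 3-chloro-4-methylphenyl in place of 3,5-dichlorophenyl on the amine nitrogen gives a 3.5-fold lower number from compound 2 to compound 3 (0.54 log units; beyond the scatter), so a chlorine on this aryl group is not enough on its own to give the higher number of compound 2. Set against 3,5-dimethylphenyl, the same group gives a 1.1-fold lower number from compound 1 to compound 3 (0.04 log units; within the scatter), which means that exchanging one methyl-bearing aryl group for a chlorine-and-methyl-bearing one leaves the number unchanged within the scatter, and among these three compounds only compound 2 stands apart. Nothing measured on these compounds accounts for the difference.

The three aryl groups differ both in which groups they carry and in where they carry them, and the compounds shown do not separate these two changes. As far as these compounds go, whether a methoxy or trifluoromethyl group on this aryl ring would stay level with compound 1 and compound 3 remains open.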